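The source may hold more compounds than are shown below. What is called first, only, known or untested is meant among the compounds shown, and "the series" means these compounds.

Working notes on the series.

Compound 1 `Cc1cc(C(=O)NCc2ccccc2)nn1Cc1cc(Cl)ccc1OCc1ccccc1` carries a benzylcarbamoyl group on the core. In a physicochemical assay for lipophilicity, at pH 7.4 (a lower number here means a more polar compound, a higher number a more lipophilic compound), compound 1 gives > 3.7, which is a limit of the assay and not a number. Compound 2 `Cc1cc(C(=O)NCc2ccccn2)nn1Cc1cc(Cl)ccc1OCc1ccccc1` differs from compound 1 by pyridin-2-yl in place of phenyl on a saturated chain carbon bound to an amide-type nitrogen. In this assay compound 2 gives > 3.7, again a limit and not a number. The step that the two limits leave unreadable from compound 1 to compound 2 is therefore not readable because the limit of > 3.7 in this assay, at which 2 of the 3 values shown sit, covers both ends of it. Within the data shown here, compound 3 `Cc1cc(NC(=O)OCc2ccccc2)nn1Cc1cc(Cl)ccc1OCc1ccccc1` differs from compound 1 by (benzyloxycarbonyl)amino in place of benzylcarbamoyl on an aromatic carbon; in this assay compound 3 gives 3.1, the only plain number in the set, and the step of a number at least 0.60 log units lower from compound 1 to compound 3 (beyond the scatter) marks it off from compound 1. The step of a number at least 0.60 log units lower from compound 2 to compound 3 (beyond the scatter) does the same from compound 2.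

Compound 4 `Cc1cc(NC(=O)OCc2ccccn2)nn1Cc1cc(Cl)ccc1OCc1ccccc1` is not yet measured. It differs from compound 3 by pyridin-2-yl in place of phenyl on a saturated chain carbon bound to an oxygen next to a carbonyl group. This is the same kind of change as that from compound 1 to compound 2, not the same: there the place is on a saturated chain carbon bound to an amide-type nitrogen, here it is on a saturated chain carbon bound to an oxygen next to a carbonyl group. For compound 4 the expected step is a number 1.10 log units lower from compound 3 to compound 4 (beyond the scatter), resting on the counted difference (pyridin-2-yl in place of phenyl on a saturated chain carbon bound to an oxygen next to a carbonyl group), since the pair compound 1 and compound 2 gives no readable size. It rests too on the number that compound 3 gives, 3.1. Compound 4 is thus estimated at 2, expected between 1.4 and 2.7.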

Compound 4, distribution coefficient: 3.1
Compound 4: middle estimate off by 1.10 log units, on the low side; the measured number lies above the stated range.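

In this assay, pyridin-2-yl in place of phenyl on a saturated chain carbon bound to an oxygen next to a carbonyl group gives no change at the digits printed from compound 3 to compound 4 (within the scatter), so on this core the exchange shows no readable effect. The replacement of the linking group gives a number at least 0.60 log units lower from compound 2 to compound 4 (beyond the scatter) and also a number at least 0.60 log units lower from compound 1 to compound 4 (beyond the scatter), so both carbamoyl compounds stand apart from compound 4, but these steps say nothing about the ring exchange itself. Whether the result carries over from one core to the other is not shown, as the same exchange on a saturated chain carbon bound to an amide-type nitrogen cannot be read because both of its ends sit at a limit: the limit of > 3.7 in this assay, at which 2 of the 4 values shown sit.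

As far as these compounds go, the size of the exchange on the amide-type side remains open, and one carbamate pair does not make a pattern. Also open, from the compounds shown here alone, is how pyridin-3-yl, or a dimethylamino group or carboxylic acid on the benzyl ring, would read in this assay.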